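Saturated linker analogue of compound 3

The source may hold more compounds than are shown below. What is called first, only, known or untested is meant among the compounds shown, and "the series" means these compounds.

Measured compounds:
compound 1 `CNC(=O)c1c(O)ccc2cc(-c3cccc(O)c3)ccc12` 76%
compound 2 `O=C(Nc1ccccc1)c1c(O)ccc2cc(-c3cccc(O)c3)ccc12` 80%
compound 3 `CNC(=O)/C=C/c1c(O)ccc2cc(-c3cccc(O)c3)ccc12` 58%

In an in vitro assay on Sf9 cells for inhibition of 17-beta-hydroxysteroid dehydrogenase type 1 (Homo sapiens), tested at 1 uM (a higher number here means a stronger effect of the compound at the concentration tested, a lower number a weaker effect), compound 3 stands lowest of the three numbers, with compound 1 nearest by a number 18 percentage points lower from compound 1 to compound 3 (beyond the scatter) and compound 2 furthest by a number 22 percentage points lower from compound 2 to compound 3 (beyond the scatter). Compound 4 `CNC(=O)CCc1c(O)ccc2cc(-c3cccc(O)c3)ccc12` is not yet measured. Its change from compound 3 is 2-(methylcarbamoyl)ethyl in place of 2-(methylcarbamoyl)ethenyl on an aromatic carbon. Among the compounds with values here, no measured step touches the double bond in this linker; the steps from compound 1 and compound 2 to compound 3 concern the insertion of the ethenyl linker itself, and the step of a number 4 percentage points higher from compound 1 to compound 2 (within the scatter) concerns the amide substituent. Within the data shown here, there is thus no step that bears directly on saturation, so no step beyond the scatter is expected, a number 2 percentage points lower from compound 3 to compound 4 (within the scatter). Compound 4 is estimated at 56%, range 36% to 74%.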

Compound 4, a percentage reported as inhibition, at one concentration (the size of the read-out at that concentration, not a potency): 80%
Beside the measured number, compound 4's estimate is 24 percentage points below it, outside the stated range (above it).
By their numbers in this assay, from the lowest: compound 3; then compounds 1, 2 and 4 (each within the scatter of the next).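

In this assay, 2-(methylcarbamoyl)ethyl in place of 2-(methylcarbamoyl)ethenyl gives a number 22 percentage points higher from compound 3 to compound 4 (beyond the scatter), so among these compounds the lower number of compound 3 goes with the double bond and not with the chain as such. This aromatic carbon carries the saturated chain as well as either carbamoyl group, with no change at the digits printed from compound 2 to compound 4 (within the scatter) and a number 4 percentage points higher from compound 1 to compound 4 (within the scatter). Nothing available explains the step.

Open, going by these compounds, is whether a longer chain or a carboxylic acid at this position holds the read-out. Also open, on these data alone, is whether a phenyl on the amide nitrogen of the saturated chain does.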